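A few compounds are considered here, and "the series" means these few. Any claim that something is new, unique, unknown or untested is made for them only; others in the source may bear on it.

The measured compounds and their values:

Compound 1, `COc1ccc2nc(C)cc(NCc3ccc(OC(F)F)cc3)c2c1`, gives 10400 nM.
Compound 2, `COc1ccc2nc(C)cc(NCc3cccc(OC(F)F)c3)c2c1`, gives 10300 nM.
Compound 3, `COc1ccc2nc(C)cc(NCc3ccc(N(C)C)cc3)c2c1`, gives 15100 nM.

These three were tested in a functional assay on MCF-10A cells (Homo sapiens) for antiproliferative activity, with a stated time of 48 h; on this read-out higher numbers stand for an effect only at larger amounts of compound and lower numbers for an effect already at smaller amounts. Compound 1 and compound 2 carry the same atoms joined differently; how the two cores differ is not broken down here. Compound 3 is reached from compound 1 by the change (dimethylamino in place of difluoromethoxy on an aromatic carbon), and this made a step of a 1.5-fold higher number from compound 1 to compound 3 (0.16 log units; within the scatter). The same kind of change leads from compound 2 to compound 4, `COc1ccc2nc(C)cc(NCc3cccc(N(C)C)c3)c2c1`, which has not been measured: dimethylamino in place of difluoromethoxy on an aromatic carbon. The two changes are the same kind, not the same, since in compound 3 the entering group stands para to a large group and in compound 4 it stands meta to a large group.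

Because the step of a 1.5-fold higher number from compound 1 to compound 3 (0.16 log units; within the scatter) lay within the scatter, the step from compound 2 to compound 4 in this assay is expected to be of similar size, a 1.5-fold higher number from compound 2 to compound 4 (0.16 log units; within the scatter). This expectation rests on the measured value of compound 2, which gives 10300 nM. Compound 4 is therefore estimated to give 15000 nM in this assay.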

Compound 4, half-maximal effective concentration: 14000 nM
Compound 4: the middle estimate sits 1.1-fold (0.03 log units) above what was measured; the range from low to high includes it.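

In this assay, dimethylamino in place of difluoromethoxy gave a step of a 1.4-fold higher number from compound 2 to compound 4 (0.13 log units; within the scatter), and set beside the earlier step on the other core, the two agree: the same change on two cores in this assay, a 1.5-fold higher number (0.16 log units; within the scatter) from compound 1 to compound 3 and a 1.4-fold higher number (0.13 log units; within the scatter) from compound 2 to compound 4, 1.1-fold (0.03 log units) apart, within the scatter of two such steps

Within these two pairs, then, the change carried from the core of compound 1 to the core of compound 2, where the entering group stands meta to a large group, without any visible difference in the size of the step. This does not show that the change has a real effect, since each step lies within the scatter, and two pairs of compounds give no rule for other cores in the series.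

The compounds shown leave open whether a carboxylic acid, a primary amine or a longer chain in that place would move the number beyond the scatter. They also leave open whether the agreement between the two steps would hold on a core altered elsewhere.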